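A Pyrrole Ketone in Place of the Methoxyphenyl of Compound 2

The source may hold more compounds than are shown below. What is called first, only, known or untested is meant among the compounds shown, and "the series" means these compounds.

Of the compounds shown here, three sharing a common core have so far been measured in a functional assay on MDA-MB-231 cells (Homo sapiens) for antiproliferative activity, read by XTT assay, with a stated time of 72 h; a lower number here means a stronger inhibitor, a higher number a weaker inhibitor. Compound 1 `COc1ccc(-c2cc3ccccc3nc2/C=C/C(=O)c2ccc(F)cc2)cc1` gives 830 nM, compound 2 `COc1ccc(C(=O)/C=C/c2nc3ccccc3cc2-c2ccc(OC)cc2)cc1` gives 7540 nM, and compound 3 `COc1ccc(-c2cc3ccccc3nc2/C=C/C(=O)c2ccc(OC)c(OC)c2)cc1` gives 4790 nM. Compound 2 thus stands at the highest number of the three: its value and that of compound 3 lie within the scatter of each other, whereas a 9.1-fold higher number from compound 1 to compound 2 (0.96 log units; beyond the scatter) is a clear difference.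

Compound 4 `COc1ccc(-c2cc3ccccc3nc2/C=C/C(=O)c2ccc[nH]2)cc1` differs from compound 2 by 1H-pyrrol-2-yl in place of 4-methoxyphenyl on a carbonyl carbon. Two measured steps change the group on the carbonyl carbon and so bear on this: a 9.1-fold higher number from compound 1 to compound 2 (0.96 log units; beyond the scatter) and a 5.8-fold higher number from compound 1 to compound 3 (0.76 log units; beyond the scatter), each a modest worsening when a methoxy-bearing ring replaces the 4-fluorophenyl there. Among the measured compounds the 4-methoxyphenyl on the carbonyl carbon therefore goes with the highest number, and its removal in compound 4 points toward a lower number, though no measured step involves a 1H-pyrrol-2-yl, so the size remains uncertain. Compound 4 is therefore expected to give about 3000 nM, with a range from 800 nM to 12000 nM. The estimated step is a 2.5-fold lower number from compound 2 to compound 4 (0.40 log units; beyond the scatter).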

Compound 4, half-maximal inhibitory concentration: > 10000 nM
Compound 4 gave a limit, no number (the forecaster's own chance of this, stated with the estimate: 5%); middle value at least 3.3-fold (0.52 log units) from the limit.
By their numbers in this assay, from the lowest: compound 1; then compounds 3 and 2 (each within the scatter of the next). At a limit, above all of these: compound 4.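

In this assay compound 4 gives no number but a limit: the limit of > 10000 nM in this assay, at which 1 of the 4 values shown sits. Set against the other compounds, an at least 2.0-fold higher number from compound 3 to compound 4 (0.31 log units; beyond the scatter) and an at least 12-fold higher number from compound 1 to compound 4 (1.08 log units; beyond the scatter), both beyond the scatter, whereas an at least 1.3-fold higher number from compound 2 to compound 4 (0.12 log units; that floor lies within the scatter) has a floor within the scatter, so compound 4 cannot be placed in order against compound 2. The new result shows that losing the 4-methoxyphenyl on the carbonyl carbon does not by itself bring the number down: the earlier compounds showed only that methoxy-bearing rings there did worse than 4-fluorophenyl, while the 1H-pyrrol-2-yl, the one five-membered ring shown at this place, recovers nothing, and among these four compounds the 4-fluorophenyl alone goes with a clearly lower number.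

As far as these compounds go, how far compound 4 lies past its limit stays open, and so does whether the pyrrole's hydrogen on nitrogen matters, which a pyrrole carrying a methyl on that nitrogen would address. Also open, from the compounds shown here alone, is whether the fluorine itself is what sets compound 1 apart, a question that an unsubstituted phenyl or a 4-chlorophenyl on the carbonyl carbon would put to the test.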